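The compounds below may be only part of what the source reports. "The series", "measured", "known", "first", "only" and "open" are said of these compounds alone.

Measured compounds and their values in an ADME assay on microsomes from liver (Homo sapiens) for metabolic stability, tested at 2.5 uM; a higher number here means faster removal of the compound, a lower number slower removal:

- compound 1 `Clc1ccc(Cn2nnc3c(Br)cccc32)cc1` gives 0.6 mL/min/g
- compound 2 `Brc1ccc(Cn2nnc3c(Br)cccc32)cc1` gives 0.4 mL/min/g
- compound 3 `Brc1cccc2c1nnn2CC1CC1` gives 1.3 mL/min/g

Compound 4 `Clc1cccc2c1nnn2CC1CC1` has not yet been measured in this assay.

Compounds 1 and 2 share one core, and the only difference between them is the change (chloro in place of bromo on an aromatic carbon). The step that goes with it is a 1.5-fold higher number from compound 2 to compound 1 (0.18 log units; within the scatter), so the two values cannot be told apart by this kind of measurement.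

Compound 3 carries a different core; the difference between the core of compound 3 and the core of compound 2 is not broken down here. Among the three measured compounds, compound 3 gives the highest number, and its gaps to compound 1 and to compound 2 are beyond the usual scatter.

Compound 4 is related to compound 3 by the change (chloro in place of bromo on an aromatic carbon). For the measured compounds named here, this is the same kind of change as the one from compound 2 to compound 1, but the surroundings differ: in compound 1 the chloro sits para to a large group, whereas in compound 4 it sits on a ring that is part of a fused or bridged system of two rings, ortho to a fused ring and meta to a fused ring.

For compound 4 the expected step in this assay is a 1.2-fold higher number from compound 3 to compound 4 (0.06 log units; within the scatter), set beside the earlier one, because a 1.5-fold higher number from compound 2 to compound 1 (0.18 log units; within the scatter) stayed within the scatter and compound 3 gives 1.3 mL/min/g. On that basis compound 4 is estimated at 1.5 mL/min/g, with a likely range from 0.8 mL/min/g to 2.8 mL/min/g.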

Compound 4, intrinsic clearance in a liver preparation (reported as CLH), per the amount of preparation that the assay uses: 4.2 mL/min/g
Estimate against measurement, compound 4: 2.8-fold (0.45 log units) below; measured number outside the range, above it.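

In this assay, chloro in place of bromo on an aromatic carbon gives a 3.2-fold higher number from compound 3 to compound 4 (0.51 log units; beyond the scatter), so on this core the swap is a real, if modest, difference rather than measurement noise. Set side by side, the steps on the two cores are no further apart than repeated measurements of this kind can be expected to fall: the same change on two cores in this assay, a 1.5-fold higher number (0.18 log units; within the scatter) from compound 2 to compound 1 and a 3.2-fold higher number (0.51 log units; beyond the scatter) from compound 3 to compound 4, 2.2-fold (0.33 log units) apart, within the scatter of two such steps. For the compounds shown here, this gives no firm sign that the core alters the effect of the change, yet it does not show that the effect carries over unchanged either, since one step can be told apart from the scatter, the other cannot, and each core offers only a single pair of compounds.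

The compounds shown leave open how this swap behaves on any further core, and so whether a step as clear as the one on the core of compound 3 is typical of the series or particular to that core. They also leave open what other groups on the same aromatic carbon would do to the removal rate, such as fluoro, methyl, a nitrile or an amine.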